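From 2,4-dichlorophenyl to 4-bromophenyl in compound 3

The source may report more compounds than this note shows. Statements on the series, on what has been measured and on what is new or still open speak of the compounds shown alone.

Measured in a functional assay on DU-145 cells (Homo sapiens) for inhibition, read by trypan blue exclusion, with a stated time of 96 h; on this read-out lower numbers stand for stronger inhibition of growth and higher numbers for weaker inhibition of growth:
- compound 1 `O=C(/C(=C\c1ccc(Br)cc1)Sc1ccc(Br)cc1)c1ccc(Br)cc1`: 1000 nM
- compound 2 `COc1ccc(S/C(=C/c2ccc(Cl)cc2Cl)C(=O)c2ccc(Br)cc2)cc1`: 1000 nM

Compound 2 stands level with compound 1, so the two measured compounds cannot be told apart here. Compound 3 `COc1ccc(S/C(=C/c2ccc(Br)cc2)C(=O)c2ccc(Br)cc2)cc1` is not yet measured. It differs from compound 2 by one change: 4-bromophenyl in place of 2,4-dichlorophenyl on a double-bonded chain carbon bound to a double-bonded chain carbon. For the measured compounds named here, no measured step shows what this swap does. However, compound 1 also carries 4-bromophenyl and gives 1000 nM, while compound 2 gives 1000 nM. In this assay the expected change is no change at the digits printed from compound 2 to compound 3 (within the scatter), with no step beyond the scatter in either direction. For compound 3 the estimated value is 1000 nM, with an expected range from 450 nM to 2200 nM.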

Compound 3, concentration for 50% growth inhibition: 20000 nM
Compound 3: middle estimate off by 20-fold (1.30 log units), on the low side, outside the stated range (above it).
By their numbers in this assay, from the lowest: compounds 1 and 2 (each within the scatter of the next); then compound 3.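

In this assay, the group on this double-bonded chain carbon clearly matters: 4-bromophenyl in place of 2,4-dichlorophenyl gives a 20-fold higher number from compound 2 to compound 3 (1.30 log units; beyond the scatter). With 4-bromophenyl held in place, a second swap, methoxy in place of bromo on an aromatic carbon, gives a 20-fold higher number from compound 1 to compound 3 (1.30 log units; beyond the scatter). Nothing measured here explains either step. Still open, as far as these compounds go, is how a compound carrying both 2,4-dichlorophenyl and bromo would read. Also open, from the compounds shown here alone, is whether a carboxylic acid or an amine on this phenyl ring would keep the number low.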